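The compounds below may be only part of what the source reports. "The series", "measured", "known", "first", "only" and "open" are said of these compounds alone.

Measured so far:
- compound 1 `COc1ccc(NC(=S)Nc2nc(C(=O)NCc3ccccc3)cs2)cc1`: 22900 nM
- compound 2 `COc1ccc(NC(=S)Nc2nc(C(=O)NCCCc3ccccc3)cs2)cc1`: 57500 nM

In a functional assay on HeLa cells (Homo sapiens) for antiproliferative activity, read by MTT assay, with a stated time of 72 h (a lower number here means a stronger inhibitor, a higher number a weaker inhibitor), compound 1 gives 22900 nM, the lower of the two numbers, and compound 2 gives 57500 nM. Compound 3 `O=C(NCc1ccccc1)c1csc(NC(=S)Nc2ccc(Cl)cc2)n1` keeps the core of compound 1 and carries chloro in place of methoxy on an aromatic carbon, para to a large group (chloro in place of methoxy on an aromatic carbon). Within the data shown here, the only measured step, a 2.5-fold higher number from compound 1 to compound 2 (0.40 log units; beyond the scatter), is a modest one and lies at another place in the structure, where phenethyl stands in place of phenyl. Among the measured compounds shown here, it therefore gives only a rough scale, and no measurement yet tests a change on this aromatic ring. No firm direction can be drawn from the data, so no shift beyond the scatter is expected. The expected change is a 1.3-fold lower number from compound 1 to compound 3 (0.10 log units; within the scatter). For compound 3 the estimated value is 18000 nM, with an expected range from 6000 nM to 50000 nM.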

Compound 3, half-maximal inhibitory concentration: 76000 nM
Compound 3: the middle estimate sits 4.2-fold (0.63 log units) below what was measured; measured number outside the range, above it.
By their numbers in this assay, from the lowest: compound 1; then compounds 2 and 3 (each within the scatter of the next).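

In this assay, the aromatic ring that the earlier step did not touch proves responsive: chloro in place of methoxy, para to a large group, gives a 3.3-fold higher number from compound 1 to compound 3 (0.52 log units; beyond the scatter) and so moves the number beyond the scatter. Among these compounds, this modest step is the first reading at this position, and in this pair the methoxy form holds the lower number, which the single earlier step, at the chain on the amide nitrogen, could not show. Nothing available bears on why the two groups differ in this way.

From the compounds shown here alone, whether the lower number belongs to methoxy in particular stays open, since a single pair cannot separate it from other groups such as hydroxyl, methyl, fluoro or an amine at this place. Also open, going by these compounds, is whether the same step would hold on the longer chain of compound 2.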